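Fluorophenyl return on the amine nitrogen

This account rests on a few compounds, and the source may have more. Where it says the series, first, only, none or still open, it means among the compounds named here.

Values in a functional assay on MGC-803 cells (Homo sapiens) for inhibition, read by sulforhodamine B assay (on this read-out higher numbers stand for weaker inhibition and lower numbers for stronger inhibition), are as follows
- compound 1 `O=C1C=C(NCc2ccccc2)C(=O)c2c1nc1n2[C@H]2OC[C@@H](O)[C@H]2OC1` gives 2670 nM
- compound 2 `O=C1C=C(Nc2ccccc2F)C(=O)c2c1nc1n2[C@H]2OC[C@@H](O)[C@H]2OC1` gives 2080 nM
- compound 3 `O=C1C=C(NC2CCCCC2)C(=O)c2c1nc1n2[C@H]2OC[C@@H](O)[C@H]2OC1` gives > 8000 nM (a limit)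

Compound 3 stands at > 8000 nM as a limit of the assay and not a number (the limit of > 8000 nM in this assay, at which 1 of the 3 values shown sits).

Compound 4 `O=C1C=C(Nc2cccc(F)c2)C(=O)c2c1nc1n2[C@H]2OC[C@@H](O)[C@H]2OC1` carries 3-fluorophenyl in place of cyclohexyl on an amine nitrogen.

The closest measured change is the reverse kind, an at least 3.8-fold higher number from compound 2 to compound 3 (0.58 log units; beyond the scatter), with an at least 2.9-fold higher number from compound 1 to compound 3 (0.47 log units; beyond the scatter) alongside it, while a 1.3-fold lower number from compound 1 to compound 2 (0.11 log units; within the scatter) stays within the scatter. A lower number in this assay is therefore expected, of at least modest size.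

The expected step is an at least 3.4-fold lower number from compound 3 to compound 4 (0.54 log units; beyond the scatter).

Compound 4 is estimated at 2300 nM, with an expected range of 900 nM to 6000 nM.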

Compound 4, half-maximal inhibitory concentration: 2180 nM
For compound 4 the middle estimate is 1.1-fold (0.02 log units) above the measured one; measured number inside the range.
By their numbers in this assay, from the lowest: compounds 2, 4 and 1 (each within the scatter of the next). At a limit, above all of these: compound 3.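

In this assay, 3-fluorophenyl and 2-fluorophenyl on the amine nitrogen cannot be told apart, with a 1.0-fold higher number from compound 2 to compound 4 (0.02 log units; within the scatter), and benzyl reads the same, with a 1.2-fold lower number from compound 1 to compound 4 (0.09 log units; within the scatter). The value of compound 3 is a limit and not a number: the limit of > 8000 nM in this assay, at which 1 of the 4 values shown sits. Even so, 3-fluorophenyl in place of cyclohexyl gives an at least 3.6-fold lower number from compound 3 to compound 4 (0.56 log units; beyond the scatter), so a second fluorophenyl now stands apart from cyclohexyl, with all three aromatic groups shown on one side.

Open, on these data alone, is how a plain phenyl, a 4-fluorophenyl or a longer chain ending in an amine would read on this nitrogen.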